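Compound 3 to compound 4: replacing the 4-hydroxyphenyl group

A few compounds are considered here, and "the series" means these few. Any claim that something is new, unique, unknown or untested is made for them only; others in the source may bear on it.

Measured in an ADME assay on the whole organism (Mus musculus, strain Swiss Webster) for pharmacokinetics, read by LC-MS, at a dose of 50 mg/kg by the oral route; a lower number here means less compound in the circulation, a higher number more compound in the circulation at the dose given:
- compound 1 `O=C(Nc1ccc(F)c(-c2nc3ncc(-c4cccc(F)c4F)cc3[nH]2)c1)N1CCCC1`: 4750 ng.h/mL
- compound 2 `O=C(Nc1ccc(F)c(-c2nc3ncc(-c4cccnc4F)cc3[nH]2)c1)N1CCCC1`: 30900 ng.h/mL
- compound 3 `O=C(Nc1ccc(F)c(-c2nc3ncc(-c4ccc(O)cc4)cc3[nH]2)c1)N1CCCC1`: 137 ng.h/mL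

Compound 3 holds the lowest of the three numbers, with compound 1 nearest and compound 2 furthest. Compound 4 `O=C(Nc1ccc(F)c(-c2nc3ncc(-c4cc(F)cc(F)c4)cc3[nH]2)c1)N1CCCC1` has 3,5-difluorophenyl in place of 4-hydroxyphenyl on an aromatic carbon. Both measured steps that bring in this same 4-hydroxyphenyl group are large: a 35-fold lower number from compound 1 to compound 3 (1.54 log units; beyond the scatter), and a 230-fold lower number from compound 2 to compound 3 (2.35 log units; beyond the scatter). The closer guide is compound 1, which also carries a difluorophenyl group, as 2,3-difluorophenyl, and gives 4750 ng.h/mL. The modest 6.5-fold higher number from compound 1 to compound 2 (0.81 log units; beyond the scatter) shows that the groups other than 4-hydroxyphenyl also differ among themselves. Within the data shown here, no measured compound carries 3,5-difluorophenyl, so the landing point stays uncertain. A large rise in this assay is therefore expected, close in size to the step involving compound 1 but opposite in direction. The expected change is a 40-fold higher number from compound 3 to compound 4 (1.60 log units; beyond the scatter). The estimate for compound 4 is 5500 ng.h/mL, with an expected range of 1500 ng.h/mL to 20000 ng.h/mL.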

Compound 4, area under the concentration-time curve: 9400 ng.h/mL
For compound 4 the middle estimate is 1.7-fold (0.23 log units) below the measured one; measured number inside the range.
By their numbers in this assay, from the lowest: compound 3; then compounds 1 and 4 (each within the scatter of the next); then compound 2.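

In this assay, replacing 4-hydroxyphenyl with a third group again gives a large change, a 69-fold higher number from compound 3 to compound 4 (1.84 log units; beyond the scatter), so compound 3 stays lowest against every other group shown at this position on the shared core. The two difluorophenyl groups cannot be told apart, with a 2.0-fold higher number from compound 1 to compound 4 (0.30 log units; within the scatter), so changing 2,3-difluorophenyl to 3,5-difluorophenyl has no readable effect in this pair. The 2-fluoropyridin-3-yl group still stands apart from 3,5-difluorophenyl, with a 3.3-fold lower number from compound 2 to compound 4 (0.52 log units; beyond the scatter), so the high number of compound 2 is not matched by either difluorophenyl compound.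

No measurement at hand accounts for any of these differences. Going by these compounds, it remains open where 4-methoxyphenyl, or a phenyl ring carrying an amine or a carboxylic acid, would fall between compound 3 and compound 2.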